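The source may report more compounds than this note shows. Statements on the series, on what has been measured and on what is new or still open speak of the compounds shown alone.

Three compounds have been measured in an ADME assay on J774 cells (Mus musculus) for cytotoxicity, read by MTT assay, with a stated time of 48 h, tested at 50 ug/mL; a higher number here means a weaker effect of the compound at the concentration tested, a lower number a stronger effect:

compound 1 `O=C(N/N=C/c1ccccc1)c1cnccn1` gives 100%
compound 2 `O=C(N/N=C/c1cccc(F)c1)c1cnccn1` gives 49%
compound 3 `CCOc1ccc(/C=N/NC(=O)c2cnccn2)cc1` gives 100%

Compound 1 stands level with compound 3 at the digits given, and together they hold the highest of the three numbers. Compound 2 lies furthest from them: a number 51 percentage points lower from compound 1 to compound 2 (beyond the scatter). Compound 4 `N#Cc1ccccc1/C=N/NC(=O)c1cnccn1` differs from compound 1 by cyano in place of hydrogen on an aromatic carbon. Among the measured compounds shown here, no measured step involves a cyano group, so only the two substitutions on the same ring bear on it: no change at the digits printed from compound 1 to compound 3 (within the scatter), whereas a number 51 percentage points lower from compound 1 to compound 2 (beyond the scatter). One substituent left the number where it was and the other lowered it sharply, so the outcome for compound 4 is uncertain, and a moderate fall with a wide range is the most that can be expected. Compound 4 is therefore estimated to give 80%, between 40% and 100%, which means an expected step of a number 20 percentage points lower from compound 1 to compound 4 (beyond the scatter).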

Compound 4, a percentage reported as activity, at one concentration (the size of the read-out at that concentration, not a potency): 92%
The estimate for compound 4 lay 12 percentage points below the measured number, and the stated range covers the measured number.
By their numbers in this assay, from the lowest: compound 2; then compounds 4, 1 and 3 (each within the scatter of the next).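

In this assay, cyano in place of hydrogen on an aromatic carbon, ortho to a large group, gives a number 8 percentage points lower from compound 1 to compound 4 (within the scatter). A second substituent on this ring, after the ethoxy of compound 3, thus stays within the scatter of compound 1, and among the three substituents only the fluoro of compound 2 stands apart. No evidence at hand accounts for this difference between the substituents.

From the compounds shown here alone, whether an amine or a carboxylic acid on this ring would stay level with compound 1 or fall towards compound 2 remains open. Also open, going by these compounds, is how cyano would behave on another carbon of the ring.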